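The source may report more compounds than this note shows. Statements on the series, on what has been measured and on what is new or still open speak of the compounds shown alone.

Measured so far:

compound 1, `COc1cccc(CNCCCNc2ccnc3cc(Oc4ccccc4)ccc23)c1O` — 9.28
compound 2, `CC(C)Cc1ccc2c(NCCCNCc3ccco3)ccnc2c1` — 9.47

In a physicochemical assay for acid dissociation, compound 2 gives 9.47, and compound 1 gives 9.28. Among the compounds with values here, the gap between these two numbers lies within the usual scatter of the measurement, so the two compounds cannot be told apart on this read-out; only two compounds have been measured, and no step between them is recorded.

The unmeasured compound 3, `CCC(CC)c1ccc2c(NCCCNCc3ccco3)ccnc2c1`, comes from compound 2 by one change: pentan-3-yl in place of isobutyl on an aromatic carbon. The swap exchanges one small saturated chain for another on the same aromatic carbon, leaving the rest of the molecule untouched.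

Within the data shown here, with no recorded step to go by, the expected step from compound 2 to compound 3 in this assay is no change at the digits printed from compound 2 to compound 3 (within the scatter), essentially none beyond the scatter. Compound 3 is therefore estimated at 9.47, with a range from 9.15 to 9.8.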

Compound 3, acid dissociation constant: 9.47
For compound 3 middle estimate and measured number coincide at the digits printed; the range from low to high includes it.
By their numbers in this assay, from the lowest: compounds 1, 2 and 3 (each within the scatter of the next).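

Within the data shown here, replacing isobutyl with pentan-3-yl on this aromatic carbon gives no change at the digits printed from compound 2 to compound 3 (within the scatter) in this assay and is the first comparison here of two compounds that differ in one place. At this position, then, going from a saturated chain of 4 heavy atoms to one of 5 gives two numbers that cannot be told apart on this read-out. No measured evidence on hand speaks to what lies behind this result.

The compounds shown cover only small saturated carbon chains at this position, so it remains open whether an amine, a carboxylic acid or a much longer chain there would give a number set apart from these. This single pair also cannot show whether the same swap would behave alike on another core.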